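The source may hold more compounds than are shown below. What is called first, only, known or untested is meant among the compounds shown, and "the series" means these compounds.

Measured so far in a functional assay on MCF7 cells (Homo sapiens) for antiproliferative activity, read by MTT assay, with a stated time of 72 h; on this read-out higher numbers stand for weaker inhibition and lower numbers for stronger inhibition:
- compound 1 `CC(C)=CC(=O)Nc1cccc(Oc2nc(Nc3cccc(C#N)c3)nc3c2CSCC3)c1`: > 50000 nM (a limit)
- compound 2 `C=CC(=O)Nc1cccc(Oc2nc(Nc3ccc(OC)nc3)nc3c2CSCC3)c1`: 17200 nM

Among the measured compounds shown here, compound 2, at 17200 nM, holds the only actual number so far. The other result is not a number: compound 1 gives > 50000 nM, which is a limit of the assay.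

The next compound is compound 3 `COc1ccc(Nc2nc3c(c(Oc4cccc(NC(=O)C=C(C)C)c4)n2)CSCC3)cn1`. It keeps the rest of compound 2 and changes one group: 2-methylprop-1-en-1-yl in place of vinyl on a carbonyl carbon. In other words, 2-methylprop-1-en-1-yl stands in place of vinyl on a carbonyl carbon.

For the measured compounds named here, no measured pair isolates this change, so its size in this assay can only be judged indirectly. Going by the values given here, the one pointer is compound 1, which carries the same 2-methylprop-1-en-1-yl and sits at the limit of > 50000 nM. On that basis, the expected direction is towards weaker inhibition, and compound 3 may well reach the limit too. The expected step is a 2.3-fold higher number from compound 2 to compound 3 (0.37 log units; beyond the scatter). The estimated value for compound 3 is 40000 nM, with an expected range of 16000 nM to 80000 nM.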

Compound 3, half-maximal inhibitory concentration: 22200 nM
The estimate for compound 3 lay 1.8-fold (0.26 log units) above the measured number; low and high end bracket the measured number.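

In this assay, the exchange of vinyl for 2-methylprop-1-en-1-yl on a carbonyl carbon can now be read directly, and it gives a 1.3-fold higher number from compound 2 to compound 3 (0.11 log units; within the scatter), so with 6-methoxypyridin-3-yl on the nitrogen these two groups cannot be told apart in this assay. The limit seen for compound 1 is therefore not tied to 2-methylprop-1-en-1-yl alone: that group is also present in compound 3, and 6-methoxypyridin-3-yl in place of 3-cyanophenyl on a nitrogen on an aromatic ring gives an at least 2.2-fold lower number from compound 1 to compound 3 (0.35 log units; beyond the scatter). Compound 1 gives > 50000 nM, which is a limit and not a number, so this step fixes only a minimum size: the limit of > 50000 nM in this assay, at which 1 of the 3 values shown sits.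

As far as these compounds go, it remains open whether the same flat reading holds for a saturated ethyl group or a dimethylaminomethyl-substituted vinyl on the carbonyl carbon. From the compounds shown here alone, it is also open whether the exchange of 3-cyanophenyl for 6-methoxypyridin-3-yl would read the same with vinyl on the carbonyl carbon, and how large that exchange really is.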